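The source may hold more compounds than are shown below. What is called first, only, known or untested is meant among the compounds shown, and "the series" means these compounds.

Compound 2, with the structure `CCCC[C@H](NC(=O)[C@H](CCCCN)NC(=O)[C@H](CCCNC(=N)N)NC(=O)c1ccc(/C=C2\SC(=S)N(c3ccc(Cl)cc3)C2=O)cc1)C(N)=O`, is one of three closely related compounds that share a large peptide-like core and differ only in the group attached to a ring nitrogen of that core. In an ADME assay for permeability, using PAMPA (a lower number here means that the compound crosses the layer more slowly, a higher number that the compound crosses the layer faster), compound 2 gives 1.02 10^-6 cm/s, the second highest of the three numbers. Compound 1, `CCCC[C@H](NC(=O)[C@H](CCCCN)NC(=O)[C@H](CCCNC(=N)N)NC(=O)c1ccc(/C=C2\SC(=S)N(Cc3ccc(OC)cc3)C2=O)cc1)C(N)=O`, gives 0.6 10^-6 cm/s in this assay, and compound 3, `CCCC[C@H](NC(=O)[C@H](CCCCN)NC(=O)[C@H](CCCNC(=N)N)NC(=O)c1ccc(/C=C2\SC(=O)N(C3CCCCC3)C2=O)cc1)C(N)=O`, gives 1.69 10^-6 cm/s in this assay. Within the data shown here, the three numbers lie close together, and the one measured step between compounds that differ in a single place, a 1.7-fold higher number from compound 1 to compound 2 (0.23 log units; within the scatter), is small.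

Compound 4, `CCCC[C@H](NC(=O)[C@H](CCCCN)NC(=O)[C@H](CCCNC(=N)N)NC(=O)c1ccc(/C=C2\SC(=S)N(c3ccc(OC)cc3)C2=O)cc1)C(N)=O`, has not yet been measured. It differs from compound 2 in one place: methoxy in place of chloro on an aromatic carbon. Among the measured compounds shown here, the only measured step that touches the same part of the molecule is the one from compound 1 to compound 2, which also swapped the group on that ring nitrogen and stayed within the scatter. A smaller swap of the kind made here is therefore not expected to move the number beyond the scatter in either direction. Compound 4 is expected to give about 1 10^-6 cm/s in this assay, between 0.5 10^-6 cm/s and 2 10^-6 cm/s. The expected step of a 1.0-fold lower number from compound 2 to compound 4 (0.01 log units; within the scatter) is estimated to stay within the scatter.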

Compound 4, apparent permeability: 0.59 10^-6 cm/s
Compound 4: the middle estimate sits 1.7-fold (0.23 log units) above what was measured; the range from low to high includes it.
By their numbers in this assay, from the lowest: compounds 4, 1, 2 and 3 (each within the scatter of the next, the first and the last beyond it).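

In this assay, among these compounds, the step of a 1.7-fold lower number from compound 2 to compound 4 (0.24 log units; within the scatter) is the first reading of a change on the aromatic ring itself, at the carbon para to a large group, and chloro and methoxy cannot be told apart there. The new compound also splits the earlier swap on the ring nitrogen into two single changes: alongside that first step, 4-methoxyphenyl in place of 4-methoxybenzyl gives a 1.0-fold lower number from compound 1 to compound 4 (0.01 log units; within the scatter), so with the methoxy kept, the benzyl and phenyl forms of this group also read the same, and neither part of the swap stands out from the scatter. Nothing shown gives a reason for these numbers.

The compounds shown place only chloro and methoxy on this ring carbon, so it stays open whether an amine, a carboxylic acid or a longer chain there would also stay within the scatter. From the compounds shown here alone, compound 3 differs from the other compounds in more than one place, so what its cyclohexyl group contributes on its own, apart from its carbonyl, also remains open.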